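Aryl substituent variation in an acylguanidine series

A few compounds are considered here, and "the series" means these few. Any claim that something is new, unique, unknown or untested is made for them only; others in the source may bear on it.

Two acylguanidines carrying a methylsulfonyl group have been measured. Compound 1 `Cc1cc(C2CCCCC2)c(S(C)(=O)=O)cc1C(=O)N=C(N)N` gives 22 nM in a functional assay for inhibition of sodium/hydrogen exchanger (Oryctolagus cuniculus); on this read-out lower numbers stand for stronger inhibition and higher numbers for weaker inhibition. Compound 2 `Cc1cc(OC2CCCC2)c(S(C)(=O)=O)cc1C(=O)N=C(N)N`, in which cyclopentyloxy stands in place of cyclohexyl on an aromatic carbon, gives 27 nM in this assay. The step of a 1.2-fold higher number from compound 1 to compound 2 (0.09 log units; within the scatter) is the only one measured so far. On these two numbers compound 2 stands highest, with compound 1 nearest and within the scatter of it, so no order between the two can be claimed.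

Compound 3 `Cc1cc(-n2cccn2)c(S(C)(=O)=O)cc1C(=O)N=C(N)N` has not yet been measured. It differs from compound 2 as follows: 1H-pyrazol-1-yl in place of cyclopentyloxy on an aromatic carbon. Going by the values given here, the one measured step concerns the same aromatic carbon: a 1.2-fold higher number from compound 1 to compound 2 (0.09 log units; within the scatter) stayed within the scatter when cyclopentyloxy replaced cyclohexyl. Here a five-membered aromatic ring with two hetero atoms replaces a five-membered non-aromatic ring of carbon only, a change of a different kind, so the measured step gives only weak guidance. The expectation is for no step beyond the scatter, with wider uncertainty than the measured pair alone would suggest, so compound 3 is estimated at 35 nM in this assay, with a range of 10 nM to 120 nM. The step this estimate means, a 1.3-fold higher number from compound 2 to compound 3 (0.11 log units; within the scatter), is expected to remain within the scatter.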

Compound 3, half-maximal inhibitory concentration: 25 nM
For compound 3 the middle estimate is 1.4-fold (0.15 log units) above the measured one; the measured number falls inside the stated range.
By their numbers in this assay, from the lowest: compounds 1, 3 and 2 (each within the scatter of the next).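

At the aromatic carbon ortho to a methylsulfonyl group, this assay now shows a change of ring type that stays within the scatter: a 1.1-fold lower number from compound 2 to compound 3 (0.03 log units; within the scatter) for the exchange of cyclopentyloxy for 1H-pyrazol-1-yl, and a 1.1-fold higher number from compound 1 to compound 3 (0.06 log units; within the scatter) for the exchange of cyclohexyl for 1H-pyrazol-1-yl. Going by these compounds alone, the earlier pair covered only non-aromatic rings of carbon, whereas these steps extend the same result to a five-membered aromatic ring with 2 hetero atoms, so across compounds 1, 2 and 3 the read-out separates none of the three groups and no compound goes against this. Nothing available accounts for this lack of separation.

All three groups at this carbon are rings, so the compounds shown leave open whether an amine, a carboxylic acid or an open longer alkyl chain there would also stay within the scatter. On these data alone, the methyl and methylsulfonyl groups are the same in all three compounds, so it also remains open whether the result would hold with another group, such as chlorine, in place of either one.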